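This account rests on a few compounds, and the source may have more. Where it says the series, first, only, none or still open, it means among the compounds named here.

In a functional assay with Alpha-1A adrenergic receptor (Homo sapiens) as the target, read by calcium flux (on this read-out higher numbers stand for larger maximal responses and lower numbers for smaller maximal responses), compound 3 `c1ccc(-c2nccs2)c(OCC2=NCCN2)c1` gives 102%, the highest of the three numbers shown, although its gap to compound 2 lies within the scatter. Compound 2 `c1ccc(-c2cnccn2)c(OCC2=NCCN2)c1` gives 97% in this assay, and compound 1 `c1cnc(-c2ccccc2OCC2=NCCN2)nc1` gives 90%. Within the data shown here, the step of a number 5 percentage points higher from compound 2 to compound 3 (within the scatter) is within the scatter, the step of a number 7 percentage points higher from compound 1 to compound 2 (within the scatter) is also within the scatter, and only the step of a number 12 percentage points higher from compound 1 to compound 3 (beyond the scatter) lies beyond it.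

The next compound, compound 4 `Cn1nccc1-c1ccccc1OCC1=NCCN1`, differs from compound 3 in one place: 1-methyl-1H-pyrazol-5-yl in place of 1,3-thiazol-2-yl on an aromatic carbon. All three measured steps swap the aromatic substituent on this same carbon, and none of them moved the maximal response by more than a modest amount; the whole set spans a narrow band around full response. Among the measured compounds shown here, no measured step exchanges one five-membered aromatic ring for another, so the closest guides are the small steps between compound 2 and compound 3 and between compound 1 and compound 2. Compound 4 is therefore expected to give 94% in this assay, with a likely range from 80% to 108%. The expected step of a number 8 percentage points lower from compound 3 to compound 4 (within the scatter) is estimated to stay within the scatter, with no clear direction.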

Compound 4, largest response reached (reported as maximum), in percent of the reference or control that the assay uses: 107%
Compound 4: the middle estimate sits 13 percentage points below what was measured; the measured number falls inside the stated range.
By their numbers in this assay, from the lowest: compounds 1, 2, 3 and 4 (each within the scatter of the next, the first and the last beyond it).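

Exchanging one five-membered aromatic ring for another at this carbon, with a methyl group added on the ring and the counted donors and acceptors unchanged, gives a step of a number 5 percentage points higher from compound 3 to compound 4 (within the scatter) in this assay, so the position accepts 1-methyl-1H-pyrazol-5-yl in place of 1,3-thiazol-2-yl without a clear change in maximal response. The new group also gives a step of a number 10 percentage points higher from compound 2 to compound 4 (within the scatter), and a step of a number 17 percentage points higher from compound 1 to compound 4 (beyond the scatter), so that among the listed compounds both five-membered rings now stand apart from pyrimidin-2-yl, while pyrazin-2-yl, also a six-membered ring, goes against any split by ring size, lying within the scatter of compound 1, compound 3 and compound 4. No supporting data bear on why these heteroaryl groups differ or fail to differ.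

Still open, as far as these compounds go, is whether the methyl group itself matters, which a 1H-pyrazol-5-yl group carrying only hydrogen on that nitrogen would test. Also open, from the compounds shown here alone, is whether a high maximal response survives on this carbon when the aromatic substituent gives way to a primary amine, a carboxylic acid or a longer alkyl chain.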